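Removing one propanoyl from compound 2

This account rests on a few compounds, and the source may have more. Where it says the series, first, only, none or still open, it means among the compounds named here.

compound 1 `CC(=O)O[C@H]1[C@H](O)[C@@H](CO)O[C@H]1n1cnc2c(N)ncnc21` gives -0.18
compound 2 `CCC(=O)O[C@H]1[C@H](OC(=O)CC)[C@@H](CO)O[C@H]1n1cnc2c(N)ncnc21` gives 1.1

Both values come from a physicochemical assay for lipophilicity; on this read-out lower numbers stand for lower lipophilicity and higher numbers for higher lipophilicity. Compound 2 stands highest of the two, beyond the scatter from compound 1. Compound 3 `CCC(=O)O[C@H]1[C@H](O)[C@@H](CO)O[C@H]1n1cnc2c(N)ncnc21` has not yet been measured. It differs from compound 2 by hydrogen in place of propanoyl on an oxygen on a saturated carbon. For the measured compounds named here, no step between measured compounds that differ in one place is available, so the expectation rests on the two values alone. Compound 1 gives -0.18 and serves as the lower reference. Compound 3 is expected slightly higher than that, and nearer to it than to compound 2. In this assay the expected move is a number 0.90 log units lower from compound 2 to compound 3 (beyond the scatter) and this would lie beyond the scatter. The estimate for compound 3 is 0.2 with an expected range from -0.15 to 0.55.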

Compound 3, partition coefficient: 0.19
Estimate against measurement, compound 3: 0.01 log units above; the range from low to high includes it.
By their numbers in this assay, from the lowest: compound 1; then compound 3; then compound 2.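

In this assay, hydrogen in place of propanoyl on an oxygen on a saturated carbon now has a size of its own: a number 0.91 log units lower from compound 2 to compound 3 (beyond the scatter), so propanoyloxy to hydroxy at this place is a change beyond the scatter. For the compounds shown here, the acyl chain can also be read for the first time: methyl in place of hydrogen on a saturated chain carbon bound to a carbonyl carbon gives a number 0.37 log units higher from compound 1 to compound 3 (beyond the scatter), a smaller step that also lies beyond the scatter. No measured evidence accounts for either step.

Going by these compounds alone, open is whether the upward step continues with a longer chain such as butanoyl, since only two chain lengths appear here. Also open, as far as these compounds go, is how this assay responds when the ester chain carries an amine or a carboxylic acid.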